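Replacing cyclopropyl with trifluoromethylphenyl on the sulfur arm

The source may hold more compounds than are shown below. What is called first, only, known or untested is meant among the compounds shown, and "the series" means these compounds.

Compound 1 `Cc1cc(N2CC[C@@H](C)[C@@H](N(C)c3ncnc4[nH]ccc34)C2)n2ncnc2n1` in a functional assay on BGC-823 cells (Homo sapiens) for inhibition, read by MTT assay, with a stated time of 72 h (on this read-out lower numbers stand for stronger inhibition and higher numbers for weaker inhibition), gives 67400 nM.
Compound 2 `Cc1cc(N2CC[C@@H](C)[C@@H](N(C)c3ncnc4[nH]ccc34)C2)n2nc(SCC3CC3)nc2n1` in this assay gives 36500 nM.
Compound 3 `Cc1cc(N2CC[C@@H](C)[C@@H](N(C)c3ncnc4[nH]ccc34)C2)n2nc(SCc3ccc(Br)cc3)nc2n1` in this assay gives 28000 nM.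

All three compounds share one core and differ only at a single aromatic carbon, which carries hydrogen in compound 1 and a sulfur-linked group in compounds 2 and 3. Compound 2 stands second highest of the three numbers: its nearest neighbour is compound 3, and the gap between them, a 1.3-fold lower number from compound 2 to compound 3 (0.12 log units; within the scatter), lies within the scatter, as does a 1.8-fold lower number from compound 1 to compound 2 (0.27 log units; within the scatter). Only a 2.4-fold lower number from compound 1 to compound 3 (0.38 log units; beyond the scatter) is a modest change beyond the scatter.

Compound 4 `Cc1cc(N2CC[C@@H](C)[C@@H](N(C)c3ncnc4[nH]ccc34)C2)n2nc(SCc3ccc(C(F)(F)F)cc3)nc2n1` has not been measured yet. Relative to compound 2 the change is 4-(trifluoromethyl)phenyl in place of cyclopropyl on a saturated chain carbon bound to a sulfur. Among the measured compounds shown here, the measured step that most resembles it is the one from compound 2 to compound 3, where 4-bromophenyl entered at the same place and the number changed only within the scatter. On that basis the expected step is a 1.2-fold lower number from compound 2 to compound 4 (0.09 log units; within the scatter), that is, no change beyond the scatter. Compound 4 is therefore estimated to give 30000 nM, with an expected range from 15000 nM to 60000 nM.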

Compound 4, half-maximal inhibitory concentration: 23300 nM
Compound 4: the middle estimate sits 1.3-fold (0.11 log units) above what was measured, within the range that was stated.
By their numbers in this assay, from the lowest: compounds 4, 3, 2 and 1 (each within the scatter of the next, the first and the last beyond it).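

In this assay, 4-(trifluoromethyl)phenyl in place of cyclopropyl gives a 1.6-fold lower number from compound 2 to compound 4 (0.19 log units; within the scatter), and trifluoromethyl in place of bromo on the aromatic carbon gives a 1.2-fold lower number from compound 3 to compound 4 (0.08 log units; within the scatter), so a third sulfur-linked group now falls in the same narrow band, and neither swap moves the number beyond the scatter. Adding the full (4-(trifluoromethyl)benzyl)sulfanyl group to the unsubstituted core gives a 2.9-fold lower number from compound 1 to compound 4 (0.46 log units; beyond the scatter), the largest step shown, though still a modest one; this makes a second benzyl-type arm that clears the scatter relative to hydrogen, while the smaller (cyclopropylmethyl)sulfanyl arm of compound 2 goes against any general rule by staying within it. No measurement here offers an explanation for these small differences.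

Going by these compounds, whether an amine, a carboxylic acid or a longer chain on the sulfur arm would shift the number further, beyond this narrow band, remains open. On these data alone, it is also open whether a plain benzyl arm, with hydrogen in place of bromo or trifluoromethyl, would fall in the same band, and whether an oxygen in place of the sulfur would preserve the step from hydrogen.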